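Trimming the Aryl Group on a Dichlorophenyl Lactone

This account rests on a few compounds, and the source may have more. Where it says the series, first, only, none or still open, it means among the compounds named here.

For the measured compounds named here, compound 2 `Cc1cc(-c2cc(Cl)cc(Cl)c2/C=C/[C@@H]2C[C@@H](O)CC(=O)O2)ccc1F` is one of two compounds measured in an assay for inhibition of 3-hydroxy-3-methylglutaryl-coenzyme A reductase (Rattus norvegicus) (a higher number here means a weaker inhibitor, a lower number a stronger inhibitor), where compound 2 gives 29 nM. The other, compound 1 `O=C1C[C@H](O)C[C@@H](/C=C/c2c(Cl)cc(Cl)cc2-c2ccc(Cl)c(Cl)c2)O1`, gives 25 nM in this assay, and the two values lie within the scatter of each other. Compound 3 `O=C1C[C@H](O)C[C@@H](/C=C/c2c(Cl)cc(Cl)cc2-c2cccc(F)c2)O1` differs from compound 2 in one place: 3-fluorophenyl in place of 4-fluoro-3-methylphenyl on an aromatic carbon. Going by the values given here, the only step that bears on this change, a 1.2-fold higher number from compound 1 to compound 2 (0.06 log units; within the scatter), also replaced the group on that aromatic carbon and stayed within the scatter, so no step beyond the scatter is expected here. Compound 3 is estimated at 30 nM (12 nM to 75 nM), an expected step of a 1.0-fold higher number from compound 2 to compound 3 (0.01 log units; within the scatter).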

Compound 3, half-maximal inhibitory concentration: 70 nM
Compound 3: the middle estimate sits 2.3-fold (0.37 log units) below what was measured; measured number inside the range.
By their numbers in this assay, from the lowest: compounds 1 and 2 (each within the scatter of the next); then compound 3.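

Unlike the earlier replacement on this aromatic carbon, the two new changes go beyond the scatter, so in this assay the aryl groups here are not all interchangeable. Taking 3-fluorophenyl in place of 4-fluoro-3-methylphenyl gives a 2.4-fold higher number from compound 2 to compound 3 (0.38 log units; beyond the scatter), and taking it in place of 3,4-dichlorophenyl gives a 2.8-fold higher number from compound 1 to compound 3 (0.45 log units; beyond the scatter). Nothing measured here explains this shift. The compounds shown leave open how far the aryl group can be trimmed further, and how a methoxy group or an amine on this ring would read in this assay.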